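Chloro to fluoro on the sulfonamide-bearing ring

The compounds below may be only part of what the source reports. "The series", "measured", "known", "first", "only" and "open" are said of these compounds alone.

Measured so far in a functional assay for agonist activity at growth hormone secretagogue receptor type 1 (Homo sapiens), read by FLIPR; a higher number here means a larger maximal response, a lower number a smaller maximal response:
compound 1, `C[C@@H]1CN(c2cccc(NS(=O)(=O)c3ccc(-c4ccccn4)s3)c2)C[C@H](C)N1`: 0.8
compound 2, `C[C@@H]1CN(c2ccc(Cl)c(NS(=O)(=O)c3ccc(-c4ccccn4)s3)c2)C[C@H](C)N1`: 1
compound 3, `C[C@@H]1CN(c2ccc(F)c(NS(=O)(=O)c3ccc(-c4ccccn4)s3)c2)C[C@H](C)N1`: not yet measured

Among the compounds with values here, only two numbers stand in this assay. Within the data shown here, compound 1 gives 0.8 and compound 2 gives 1; the single measured step is a number 0.20 higher from compound 1 to compound 2 (beyond the scatter). Among the measured compounds shown here, compound 2 therefore holds the highest of the two numbers, with compound 1 as its only neighbour, lower by that step.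

Compound 3 differs from compound 2 by fluoro in place of chloro on an aromatic carbon. For the measured compounds named here, no fluoro analogue has been measured, so the only step that bears on this change is the one from hydrogen to chloro at the same aromatic carbon, which was modest and beyond the scatter. Fluoro is a halogen like chloro but a smaller single atom, so the expectation is a value between the two measured numbers, nearer the chloro compound than the hydrogen compound. The step expected is a number 0.10 lower from compound 2 to compound 3 (within the scatter), at the edge of the usual scatter. For compound 3 the estimated maximal response is 0.9, with a range from 0.75 to 1.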

Compound 3, intrinsic activity: the largest response reached, as a fraction of the reference agonist's: 0.8
Compound 3: middle estimate off by 0.10, on the high side; measured number inside the range.
By their numbers in this assay, from the lowest: compounds 1 and 3 (each within the scatter of the next); then compound 2.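

In this assay, the rise seen with chloro on this aromatic carbon, ortho to a large group and para to a 3,5-dimethylpiperazin-1-yl group, does not carry over to every halogen: fluoro in place of chloro gives a number 0.20 lower from compound 2 to compound 3 (beyond the scatter). Fluoro in place of hydrogen gives no change at the digits printed from compound 1 to compound 3 (within the scatter), so at this carbon fluoro cannot be told apart from hydrogen, and compound 2 alone stands clear of the other two compounds, with the gain belonging to chloro rather than to halogen substitution as such. Nothing available explains why chloro and fluoro part at this carbon.

As far as these compounds go, how bromo, methyl, methoxy or trifluoromethyl on the same carbon would compare with chloro stays open, so it cannot yet be said whether chloro is a lone case or one member of a wider set of groups that reach the level of compound 2. Also open, from the compounds shown here alone, is whether chloro would give the same step on another carbon of this ring, since all three compounds differ only at this one place.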